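The source may report more compounds than this note shows. Statements on the series, on what has been measured and on what is new or still open speak of the compounds shown alone.

Among the compounds with values here, in an assay on HEK293 cells for inhibition of N-acylethanolamine-hydrolyzing acid amidase (Rattus norvegicus), read by LC-MS, with a stated time of 30 min (a lower number here means a stronger inhibitor, a higher number a weaker inhibitor), compound 2 `O=C(CCCCCc1ccc(O)cc1)N1CCOC1=O` gives 61 nM, the only outright number in this set. Compound 1 `O=C(CCCCCc1ccc(O)c(Cl)c1)N1CCOC1=O` reaches only the limit > 20000 nM and so sits at the limit of > 20000 nM in this assay, at which 1 of the 2 values shown sits. The step of an at least 320-fold lower number from compound 1 to compound 2 (2.51 log units; beyond the scatter) shows how strongly a change on the aromatic ring can move the number in this assay. Compound 3 `NC(=O)c1ccc(CCCCCC(=O)N2CCOC2=O)cc1` differs from compound 2 by carbamoyl in place of hydroxy on an aromatic carbon. Within the data shown here, only that one measured step bears on this change, and it was large, so a clear loss is expected in this assay, a 9.8-fold higher number from compound 2 to compound 3 (0.99 log units; beyond the scatter). Compound 3 is therefore estimated at 600 nM, with a range from 100 nM to 5000 nM.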

Compound 3, half-maximal inhibitory concentration: > 20000 nM
Compound 3 ended at the assay's limit; the forecaster's own chance of this, stated with the estimate: 15%; middle value at least 33-fold (1.52 log units) away from the limit.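

The step of an at least 320-fold higher number from compound 2 to compound 3 (2.51 log units; beyond the scatter) shows that in this assay the hydroxy, para to a large group, cannot be exchanged for carbamoyl without a large loss, although both groups carry a hydrogen-bond donor and acceptor. On these data alone, compound 3 gives > 20000 nM, which is a limit and not a number, so the full size of this step stays unknown. Both single changes from compound 2 now end at this limit: the limit of > 20000 nM in this assay, at which 2 of the 3 values shown sit.

Still open, as far as these compounds go, is whether an amine, a methoxy group or a carboxylic acid at this place would retain inhibition. Also open, from the compounds shown here alone, is how a plain hydrogen there would compare with the hydroxy of compound 2.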